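A few compounds are considered here, and "the series" means these few. Any claim that something is new, unique, unknown or untested is made for them only; others in the source may bear on it.

Measured compounds in the series:
compound 1, `CC(C)c1n[nH]c2c(NCc3ccc(-c4ccccn4)cc3)nc(SCC(O)CN3CCNCC3)nc12`, 332 nM
compound 2, `CC(C)c1n[nH]c2c(NCc3ccc(-c4ccccn4)cc3)nc(SCC(O)CN)nc12`, 55 nM
compound 3, `CC(C)c1n[nH]c2c(NCc3ccc(-c4ccccn4)cc3)nc(SCCNC(=N)N)nc12`, 390 nM

In a functional assay on HT cells (Homo sapiens) for antiproliferative activity, read by fluorescence, with a stated time of 72 h (a higher number here means a weaker inhibitor of growth, a lower number a stronger inhibitor of growth), compound 2 gives the lowest number of the three. The steps of a 6.0-fold lower number from compound 1 to compound 2 (0.78 log units; beyond the scatter) and a 7.1-fold higher number from compound 2 to compound 3 (0.85 log units; beyond the scatter) both set compound 2 apart from the others, each beyond the scatter, while compound 1 and compound 3 are separated only by a 1.2-fold higher number from compound 1 to compound 3 (0.07 log units; within the scatter), which lies within the scatter.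

Compound 4, `CC(C)c1n[nH]c2c(NCc3ccc(-c4ccccn4)cc3)nc(SCCNC(N)=O)nc12`, differs from compound 2 by ureidomethyl in place of 2-amino-1-hydroxyethyl on a saturated chain carbon bound to a sulfur. The measured step bearing most directly on this change is a 7.1-fold higher number from compound 2 to compound 3 (0.85 log units; beyond the scatter), where the group on the same saturated chain carbon bound to a sulfur was exchanged and the number rose beyond the scatter; a 6.0-fold lower number from compound 1 to compound 2 (0.78 log units; beyond the scatter) points the same way, the amino-bearing chain giving the lowest number in this assay. Among the measured compounds shown here, no measured compound carries a ureidomethyl group, so the size of the step is uncertain. A step upward of roughly the size seen for compound 3 is expected, namely a 6.4-fold higher number from compound 2 to compound 4 (0.80 log units; beyond the scatter). Compound 4 is therefore estimated at 350 nM, with a range from 120 nM to 1000 nM.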

Compound 4, concentration for 50% growth inhibition: 240 nM
The estimate for compound 4 lay 1.5-fold (0.16 log units) above the measured number; low and high end bracket the measured number.
By their numbers in this assay, from the lowest: compound 2; then compounds 4, 1 and 3 (each within the scatter of the next).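

In this assay, ureidomethyl in place of 2-amino-1-hydroxyethyl on the saturated chain carbon bound to a sulfur gives a 4.4-fold higher number from compound 2 to compound 4 (0.64 log units; beyond the scatter) and so does not keep the low number of compound 2. The ureido end of compound 4 is not told apart from the guanidino end of compound 3, with a 1.6-fold lower number from compound 3 to compound 4 (0.21 log units; within the scatter) inside the scatter, and a 1.4-fold lower number from compound 1 to compound 4 (0.14 log units; within the scatter) also stays inside it. Three different chains thus fall together and only the 3-amino-2-hydroxypropyl chain stands apart, while compound 1 shows that the hydroxyl with a piperazin-1-yl end does not share that low number.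

On these data alone, whether the free amine alone carries the gap stays open, and a plain 2-aminoethyl chain on the sulfur would test this. No measurement here accounts for the difference.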